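Moving the bromine around the phenyl ring

The source may hold more compounds than are shown below. What is called first, only, known or untested is meant among the compounds shown, and "the series" means these compounds.

Measured compounds:
Compound 1, `O=[N+]([O-])c1ccc(CN2CCC(n3cc(CC(OCc4cc(-c5ccccc5)no4)c4ccc(Br)cc4)nn3)CC2)cc1`: 7000 nM
Compound 2, `O=[N+]([O-])c1ccc(CN2CCC(n3cc(CC(OCc4cc(-c5ccc(Br)cc5)no4)c4ccc(Br)cc4)nn3)CC2)cc1`: 3000 nM

Both were tested in a functional assay on Caco-2 cells (Homo sapiens) for cytotoxicity, with a stated time of 48 h; on this read-out higher numbers stand for weaker inhibition and lower numbers for stronger inhibition. Compound 2 gives the lowest of the two numbers in this assay; the nearest, compound 1, lies higher by a 2.3-fold lower number from compound 1 to compound 2 (0.37 log units; beyond the scatter), a step described as modest but beyond the scatter, and brought about by bromo in place of hydrogen on an aromatic carbon.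

Compound 3, `O=[N+]([O-])c1ccc(CN2CCC(n3cc(CC(OCc4cc(-c5ccccc5Br)no4)c4ccc(Br)cc4)nn3)CC2)cc1`, has not been measured yet. It differs from compound 2 in one place: 2-bromophenyl in place of 4-bromophenyl on an aromatic carbon. The two compounds share every atom and differ only in where the bromine sits on the phenyl ring attached to the five-membered aromatic ring with one nitrogen and one oxygen.

Among the compounds with values here, the only measured step, from compound 1 to compound 2, shows what adding the bromine did at one place; nothing measured shows what moving it does. With no comparison of that kind at hand, the step for compound 3 in this assay is expected to stay within or near the scatter, a 1.3-fold higher number from compound 2 to compound 3 (0.12 log units; within the scatter), with the direction uncertain. Compound 3 is therefore estimated at 4000 nM, with a range from 1500 nM to 12000 nM.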

Compound 3, half-maximal inhibitory concentration: 3000 nM
The estimate for compound 3 lay 1.3-fold (0.12 log units) above the measured number, within the range that was stated.
By their numbers in this assay, from the lowest: compounds 2 and 3 (each within the scatter of the next); then compound 1.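

In this assay, the bromine on the phenyl ring can now be compared at two places on that ring: 2-bromophenyl in place of 4-bromophenyl gives no change at the digits printed from compound 2 to compound 3 (within the scatter), so the two placements cannot be told apart here. The lower number that came with adding bromine is therefore not tied to 4-bromophenyl, since bromo in place of hydrogen at the other place on the ring also gives a 2.3-fold lower number from compound 1 to compound 3 (0.37 log units; beyond the scatter). Nothing available explains why the two placements read alike.

The compounds shown leave open whether 3-bromophenyl would read like these two, and whether the step belongs to bromine in particular or would also appear with a chloro, methyl or methoxy group on the same phenyl ring. They also leave open whether the likeness of 2-bromophenyl and 4-bromophenyl would hold in any cell line other than the one used here.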